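The source may hold more compounds than are shown below. What is called first, only, known or untested is meant among the compounds shown, and "the series" means these compounds.

Working notes on the series.

Three compounds carry a measured value in a functional assay on MCF7 cells (Homo sapiens) for inhibition, read by MTT assay, with a stated time of 72 h; a higher number here means a weaker inhibitor, a lower number a stronger inhibitor. Compound 1, `CN(C(=O)NC(=O)c1c(F)cccc1F)c1nc(C(F)(F)F)c(C(=O)N/N=C/c2cccc(C(F)(F)F)c2)s1`, gives 21.8 ug/mL. Compound 2, `CN(C(=O)NC(=O)c1cccc(C(F)(F)F)c1)c1nc(C(F)(F)F)c(C(=O)N/N=C/c2cc(C(F)(F)F)cc(C(F)(F)F)c2)s1`, gives 6.08 ug/mL. Compound 3, `Cc1nc(N(C)C(=O)NC(=O)c2c(F)cccc2F)sc1C(=O)N/N=C/c1cc(C(F)(F)F)cc(C(F)(F)F)c1`, gives 11.6 ug/mL. Compound 3 stands second highest of the three numbers; its nearest neighbour is compound 1, and the gap between the two falls within the scatter of repeated measurements, while the gap to compound 2 also stays within that scatter. Within the data shown here, no single-point step between two measured compounds is available, so the three values can only be read side by side.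

Compound 4, `CN(C(=O)NC(=O)c1c(F)cccc1F)c1nc(C(F)(F)F)c(C(=O)N/N=C/c2cc(C(F)(F)F)cc(C(F)(F)F)c2)s1`, has not yet been measured. It is derived from compound 3 by one change: trifluoromethyl in place of methyl on an aromatic carbon. Compound 4 thereby shares the core of compound 2 and the hydrazone part of compound 2, and the difluorobenzoyl part of compound 1 and compound 3. Given that compound 2 gives 6.08 ug/mL and compound 3 gives 11.6 ug/mL, the step from compound 3 to compound 4 is expected to be small, toward a lower number or none beyond the scatter, as a 1.4-fold lower number from compound 3 to compound 4 (0.14 log units; within the scatter). For compound 4 the expected value is 8.5 ug/mL, within the range 3.5 ug/mL to 20 ug/mL.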

Compound 4, half-maximal inhibitory concentration: 6.85 ug/mL
Compound 4: middle estimate off by 1.2-fold (0.09 log units), on the high side; the measured number falls inside the stated range.
By their numbers in this assay, from the lowest: compounds 2, 4, 3 and 1 (each within the scatter of the next, the first and the last beyond it).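

In this assay, the aromatic carbon next to the ring nitrogen accepts trifluoromethyl in place of methyl with a 1.7-fold lower number from compound 3 to compound 4 (0.23 log units; within the scatter) as the step, so this position shows no readable preference between the two groups in this pair. Among these compounds, on the carbonyl carbon, 2,6-difluorophenyl in place of 3-(trifluoromethyl)phenyl gives a 1.1-fold higher number from compound 2 to compound 4 (0.05 log units; within the scatter) as its step, so that exchange is not readable either, while the gain of one further trifluoromethyl gives a 3.2-fold lower number from compound 1 to compound 4 (0.50 log units; beyond the scatter) as the only step here that clears the scatter, and it is a modest one. Nothing measured on these compounds gives a reason for any of the three steps.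

The compounds shown leave open how an amine, a carboxylic acid or a longer chain such as ethyl would read at the carbon next to the ring nitrogen, since only methyl and trifluoromethyl appear there. They also leave open whether the gain of one further trifluoromethyl would give a similar step with 3-(trifluoromethyl)phenyl on the carbonyl carbon or with methyl on the core.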